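Methylating the hydroxy of a naphthoquinone amide

The compounds below may be only part of what the source reports. "The series", "measured", "known", "first", "only" and "open" are said of these compounds alone.

Of the compounds shown here, two have been measured. Compound 1 `COC1=C(CC(C)(C)CNC(=O)c2ccc3ccccc3c2OC)C(=O)c2ccccc2C1=O` and compound 2 `COc1cc(C(=O)NCC(C)(C)CC2=C(O)C(=O)c3ccccc3C2=O)c(OC)c2ccccc12` share the same core and were both tested in an ADME assay on Vero cells (Chlorocebus sabaeus) for cytotoxicity, read by fluorescence, with a stated time of 4 days; on this read-out lower numbers stand for stronger inhibition and higher numbers for weaker inhibition. In this assay compound 1 gives 60600 nM, while compound 2 gives 17700 nM, so compound 2 stands as the lower of the two numbers, with compound 1 beyond the usual scatter above it.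

Compound 3 `COC1=C(CC(C)(C)CNC(=O)c2cc(OC)c3ccccc3c2OC)C(=O)c2ccccc2C1=O` has not yet been measured. It differs from compound 2 in one place: methyl in place of hydrogen on an oxygen on an unsaturated carbon, which, read one bond further out, is hydroxy turned into methoxy. Among the measured compounds shown here, no measured pair shows this exact change, so the size of the step is open. Compound 1, which likewise carries a methoxy rather than a hydroxy at this position, sits at 60600 nM, and that is the only hint available.

The expectation is therefore a move toward weaker inhibition, estimated as a 2.3-fold higher number from compound 2 to compound 3 (0.35 log units; beyond the scatter). Compound 3 is expected to come in at about 40000 nM, with a plausible range from 15000 nM to 110000 nM.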

Compound 3, half-maximal inhibitory concentration: 30100 nM
Estimate against measurement, compound 3: 1.3-fold (0.12 log units) above, and the stated range covers the measured number.
By their numbers in this assay, from the lowest: compounds 2, 3 and 1 (each within the scatter of the next, the first and the last beyond it).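

In this assay, the change from hydroxy to methoxy on the oxygen on the unsaturated carbon can now be read directly, without leaning on a compound that differs in more than one place: a 1.7-fold higher number from compound 2 to compound 3 (0.23 log units; within the scatter) lies within the usual scatter, so this single change does not clearly shift the number. The second single change, methoxy in place of hydrogen on an aromatic carbon, gives a 2.0-fold lower number from compound 1 to compound 3 (0.30 log units; within the scatter), which also lies within the scatter, so neither change read alone can be told apart from the noise of repeated measurements. Nothing available here offers an explanation for either step.

The compounds shown leave open whether a bigger group on that same oxygen, such as ethoxy, would give a step beyond the scatter, and whether an amine or a carboxylic acid in place of the methoxy on the aromatic carbon would do so. As far as these compounds go, each change is also read only once, on this one shared core, so whether either step would stay this small on a different core remains unknown.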